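The source may hold more compounds than are shown below. What is called first, only, known or untested is meant among the compounds shown, and "the series" means these compounds.

Measured in a functional assay on NCI-H23 cells (Homo sapiens) for cytotoxicity, read by colorimetric assay; a higher number here means a weaker inhibitor, a lower number a stronger inhibitor:
- compound 1 `O=C(/C=C/c1ccc(CN2C(=O)/C(=C3\Nc4ccccc4\C3=N/O)c3cccc(Cl)c32)cc1)NO`: 50 nM
- compound 2 `O=C(NO)c1ccc(CN2C(=O)/C(=C3\Nc4ccccc4\C3=N/O)c3cccc(Cl)c32)cc1`: 60 nM
- compound 3 `O=C(NO)c1ccc(CN2C(=O)/C(=C3\Nc4ccccc4\C3=N/O)c3cc(Br)ccc32)cc1`: 7 nM

Compound 1 stands close to compound 2, with a 1.2-fold higher number from compound 1 to compound 2 (0.08 log units; within the scatter). Compound 3 gives a clearly lower number, 7 nM, against compound 1 at 50 nM, so compound 1 lies in the upper part of this small set.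

The unmeasured compound 4 `O=C(/C=C/c1ccc(CN2C(=O)/C(=C3\Nc4ccccc4\C3=N/O)c3ccccc32)cc1)NO` keeps the 2-(hydroxycarbamoyl)ethenyl group of compound 1 and differs at one place: hydrogen in place of chloro on an aromatic carbon. The chloro group therefore gives way to hydrogen on an aromatic carbon of a six-membered aromatic ring of carbon only.

Going by the values given here, no measured step covers this change. Among the compounds with values here, the one available step, a 1.2-fold higher number from compound 1 to compound 2 (0.08 log units; within the scatter), replaces 2-(hydroxycarbamoyl)ethenyl with hydroxycarbamoyl and leaves the chloro group in place. The nearest hint is a pair that differs in its halogen substituent: compound 2 gives 60 nM and compound 3 gives 7 nM. Within the data shown here, these values show that compounds differing in this part of the structure can lie well apart in this assay, but no measured compound lacks a halogen.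

No direction can be argued from this, so no step beyond the scatter is expected, though the range is kept wide. The expected step is no change at the digits printed from compound 1 to compound 4 (within the scatter). For compound 4 the estimated value is 50 nM, with an expected range from 15 nM to 170 nM.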

Compound 4, half-maximal inhibitory concentration: 9 nM
Compound 4: the middle estimate sits 5.6-fold (0.74 log units) above what was measured; the measured number lies below the stated range.
By their numbers in this assay, from the lowest: compounds 3 and 4 (each within the scatter of the next); then compounds 1 and 2 (each within the scatter of the next).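

In this assay, hydrogen in place of chloro on an aromatic carbon gives a 5.6-fold lower number from compound 1 to compound 4 (0.74 log units; beyond the scatter) and thus shows that the number responds to this position, with a step beyond the scatter. The other step from compound 1, a 1.2-fold higher number from compound 1 to compound 2 (0.08 log units; within the scatter) within the scatter, changes the 2-(hydroxycarbamoyl)ethenyl group instead, so compound 1 now has a change that moves the number and one that does not. Compound 4 at 9 nM also shows that a low number in this small set needs no halogen on this ring, but nothing available explains the size or direction of the step.

As far as these compounds go, it remains open whether a fluoro, methyl, methoxy or amino group on this aromatic carbon would give a number nearer that of compound 4 or that of compound 1. It is also open whether the same exchange of chloro for hydrogen would give a step of similar size with the hydroxycarbamoyl group of compound 2, since no partner of compound 2 carrying hydrogen at this place is shown.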